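Shortening the alkanoyl chain of compound 1

A few compounds are considered here, and "the series" means these few. Any claim that something is new, unique, unknown or untested is made for them only; others in the source may bear on it.

Measured so far:
compound 1 `CCCC(=O)c1ccc(OCCCCOc2cccc(C(=O)O)c2C)c(C)c1O`: 52 nM
compound 2 `Cc1c(OCCCCOc2cccc(C(=O)O)c2)ccc(C(=O)CC(C)C)c1C`: "not active" (no number reported)
compound 3 `Cc1c(OCCCCOc2ccc(C(=O)O)c(Cl)c2)ccc(C(=O)CC(C)C)c1C`: > 10000 nM

In an assay on HEK293 cells for positive allosteric modulation of metabotropic glutamate receptor 2 (Rattus norvegicus), read by thallium flux, with a stated time of 2.5 min (on this read-out higher numbers stand for an effect only at larger amounts of compound and lower numbers for an effect already at smaller amounts), compound 1 gives 52 nM, the only numerical result among the three. Compound 2 is reported in this assay as "not active" (no number reported). For the measured compounds named here, for compound 3 the result is a limit, > 10000 nM, the one value sitting at the limit of > 10000 nM in this assay, at which 1 of the 3 values shown sits. Compound 4 `CCC(=O)c1ccc(OCCCCOc2cccc(C(=O)O)c2C)c(C)c1O` is not yet measured in this assay; it differs from compound 1 by hydrogen in place of methyl on a saturated chain carbon, two bonds along the chain from a carbonyl carbon. Going by the values given here, no measured pair shows this step, so its size is open; a change within the scatter, or at most a modest loss, is expected. For compound 4 the expected value is 100 nM, range 30 nM to 400 nM, an expected step of a 1.9-fold higher number from compound 1 to compound 4 (0.28 log units; within the scatter).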

Compound 4, half-maximal effective concentration: 62 nM
Compound 4: the middle estimate sits 1.6-fold (0.21 log units) above what was measured, within the range that was stated.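

In this assay, for the compounds shown here, the only direct pair at this position gives a 1.2-fold higher number from compound 1 to compound 4 (0.08 log units; within the scatter) for hydrogen in place of methyl on a saturated chain carbon, two bonds along the chain from a carbonyl carbon. Propylcarbonyl and propanoyl are therefore not told apart here, and this pair's activity does not depend on the carbon removed. No measured property bears on this step.

Still open, going by these compounds, is whether an acetyl group or a longer chain such as pentanoyl would hold this level. Compound 2 and compound 3 differ from compound 1 in more than one place and do not settle this.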